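A triazole aryl swap in a spirooxindole series

The source may report more compounds than this note shows. Statements on the series, on what has been measured and on what is new or still open speak of the compounds shown alone.

Compound 1 `Cc1ccc(C)c(-n2nncc2CN2C(=O)C3(C(C#N)=C(N)Oc4c3c3nc5ccccc5nc3c3ccccc43)c3ccccc32)c1` — in an ADME assay on L02 cells (Homo sapiens) for antiproliferative activity, read by MTT assay, with a stated time of 48 h (a lower number here means a stronger inhibitor, a higher number a weaker inhibitor), compound 1 gives only a limit, > 50000 nM.
Compound 2 `N#CC1=C(N)Oc2c(c3nc4ccccc4nc3c3ccccc23)C12C(=O)N(Cc1cnnn1-c1ccc(Cl)c(Cl)c1)c1ccccc12` — in this assay compound 2 gives only a limit, > 50000 nM.
Compound 3 `N#CC1=C(N)Oc2c(N)cc3nc4ccccc4nc3c2C12C(=O)N(Cc1cnnn1-c1ccccc1Br)c1ccccc12` — in this assay compound 3 gives 29200 nM.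

Among the compounds with values here, compound 3 holds the only number among the three; the two other readings sit at the limit of > 50000 nM in this assay, at which 2 of the 3 values shown sit, and are limits, not numbers. Within the data shown here, only one step between measured compounds exists, a step that the two limits leave unreadable from compound 1 to compound 2, and since both of its ends are limits its size cannot be read.

Compound 4 `Cc1ccc(-n2nncc2CN2C(=O)C3(C(C#N)=C(N)Oc4c(N)cc5nc6ccccc6nc5c43)c3ccccc32)cc1C` is to be measured in this assay. It differs from compound 3 by 3,4-dimethylphenyl in place of 2-bromophenyl on an aromatic nitrogen. Among the measured compounds shown here, the one measured step bears on this change, as it also swaps the aryl group on that aromatic nitrogen, but it tells nothing about size. What the data do show is that both compounds with an aryl group of this kind, compound 1 and compound 2, return only limits, while compound 3 with 2-bromophenyl returns a number. Compound 4 is therefore expected to weaken, with the step of a 1.7-fold higher number from compound 3 to compound 4 (0.23 log units; within the scatter) estimated to go upward, likely to or past the limit. For compound 4 the estimate in this assay is 50000 nM, expected to lie between 22000 nM and 120000 nM.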

Compound 4, half-maximal inhibitory concentration: > 50000 nM
Compound 4 ended at the assay's limit; the forecaster's own chance of this, stated with the estimate: 60%; the middle value sits exactly at the limit.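

In this assay compound 4 gives > 50000 nM, which is a limit of the assay and not a number. With 3,4-dimethylphenyl in place of 2-bromophenyl on the aromatic nitrogen of the triazole's five-membered ring, this position now has its first step with a readable floor, an at least 1.7-fold higher number from compound 3 to compound 4 (0.23 log units; that floor lies within the scatter), and the earlier aryl swap offered no such floor. Because that floor lies within the usual scatter and the reading stops at the limit, the change gives no firm size, only a lower bound, and compound 4 joins the compounds that the assay cannot resolve: the limit of > 50000 nM in this assay, at which 3 of the 4 values shown sit.

The step between compound 1 and compound 2 still cannot be read, so the shown compounds give no measured ranking of the aryl groups on the core of compound 1. From the compounds shown here alone, on the core of compound 3, it remains open how far past the limit compound 4 lies, and whether a 2-chlorophenyl, or a phenyl ring carrying an amine or a carboxylic acid, would return a number in this assay.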